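Compound 4: 2-methylphenyl in place of amino

The source may report more compounds than this note shows. Statements on the series, on what has been measured and on what is new or still open speak of the compounds shown alone.

Measured compounds:
compound 1 `Cc1c(-n2c(-c3ccccc3)c(-c3ccccc3)c3c(Nc4ccccc4)ncnc32)n(C)n(-c2ccccc2)c1=O`: 27.9%
compound 2 `Cc1c(-n2c(-c3ccccc3)c(-c3ccccc3)c3c(N/N=C/c4ccccc4)ncnc32)n(C)n(-c2ccccc2)c1=O`: 48.4%
compound 3 `Cc1c(-n2c(-c3ccccc3)c(-c3ccccc3)c3c(NN)ncnc32)n(C)n(-c2ccccc2)c1=O`: 54%

All three were tested in a functional assay on the whole organism (strain Sprague-Dawley) for inhibition, with Rattus norvegicus as the target, read by paw edema, with stated times of 1 h and 4 h, at a dose of 70 mg/kg by the subcutaneous route; on this read-out higher numbers stand for more inhibition at the one dose given (going by the name of the read-out) and lower numbers for less inhibition. Compound 3 gives the largest of the three numbers, but the nearest of them lies within the scatter of it (a number 5.6 percentage points higher from compound 2 to compound 3 (within the scatter)), and only the remaining one is clearly separated (a number 26.1 percentage points higher from compound 1 to compound 3 (beyond the scatter)).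

Compound 4 `Cc1ccccc1Nc1ncnc2c1c(-c1ccccc1)c(-c1ccccc1)n2-c1c(C)c(=O)n(-c2ccccc2)n1C` differs from compound 3 in one place: 2-methylphenyl in place of amino on a nitrogen on an aromatic ring. The step that bears on this is a number 26.1 percentage points higher from compound 1 to compound 3 (beyond the scatter), a modest rise when amino replaced phenyl. Compound 4 reverses that exchange, the entering phenyl now carrying a methyl. A modest fall beyond the scatter is therefore expected, a number 24 percentage points lower from compound 3 to compound 4 (beyond the scatter). Compound 4 is estimated at 30%, with a range from 15% to 45%.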

Compound 4, a percentage reported as inhibition, in the whole organism at one dose (the size of the read-out at that dose, not a potency): 28%
Compound 4: middle estimate off by 2 percentage points, on the high side; the measured number falls inside the stated range.
By their numbers in this assay, from the lowest: compounds 1 and 4 (each within the scatter of the next); then compounds 2 and 3 (each within the scatter of the next).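

In this assay, adding a methyl to the phenyl on this nitrogen makes no readable difference (a number 0.1 percentage points higher from compound 1 to compound 4 (within the scatter)). The 2-methylphenyl group therefore stays with phenyl at the low end, clearly apart from both amino (a number 26 percentage points lower from compound 3 to compound 4 (beyond the scatter)) and the group of compound 2 (a number 20.4 percentage points lower from compound 2 to compound 4 (beyond the scatter)). No measurement available here explains these steps. As far as these compounds go, it remains open whether methoxy or a carboxylic acid on that phenyl would move the number. From the compounds shown here alone, it is also open whether a cyclohexyl group in place of the phenyl would stand with compound 1 or with compound 3.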